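From 4-methylphenyl to 3-fluorophenyl on a shared core

The compounds below may be only part of what the source reports. "The series", "measured", "known", "first", "only" and "open" are said of these compounds alone.

Compound 1 `N=C(N)c1ccc(-c2ccc(-c3cccc([N+](=O)[O-])c3)o2)cc1`: 3300 nM
Compound 2 `Cc1ccc(-c2ccc(-c3ccc(C(=N)N)cc3)o2)cc1`: 3100 nM

In a functional assay on T47D cells (Homo sapiens) for cytotoxicity, read by MTT assay, with a stated time of 96 h (on this read-out lower numbers stand for stronger inhibition and higher numbers for weaker inhibition), compound 2 gives 3100 nM. This places it within the usual scatter of compound 1 at 3300 nM, so the two numbers cannot be ranked against each other.

The account now turns to compound 3 `N=C(N)c1ccc(-c2ccc(-c3cccc(F)c3)o2)cc1`, which differs from compound 2 at a single place: 3-fluorophenyl in place of 4-methylphenyl on an aromatic carbon. It carries 3-fluorophenyl in place of 4-methylphenyl on an aromatic carbon, next to the ring oxygen of the five-membered aromatic ring with 1 oxygen, and the rest of the structure stays the same.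

Within the data shown here, no measured pair in this small set shows a change of this kind, so there is no direct step to lean on. Among the measured compounds shown here, the only guide is that compound 1 at 3300 nM and compound 2 at 3100 nM lie within the scatter of each other. In this assay no shift beyond the scatter is therefore expected, in either direction. The expected step is a 1.0-fold lower number from compound 2 to compound 3 (0.01 log units; within the scatter). The estimate for compound 3 is 3000 nM, with an expected range from 1300 nM to 7000 nM.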

Compound 3, half-maximal inhibitory concentration: 2800 nM
Beside the measured number, compound 3's estimate is 1.1-fold (0.03 log units) above it; the measured number falls inside the stated range.
By their numbers in this assay, from the lowest: compounds 3, 2 and 1 (each within the scatter of the next).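

In this assay, the exchange on the aromatic carbon next to the ring oxygen gives a 1.1-fold lower number from compound 2 to compound 3 (0.04 log units; within the scatter), and fluoro in place of nitro gives a 1.2-fold lower number from compound 1 to compound 3 (0.07 log units; within the scatter). Among these compounds, these are the first steps that can be read in this set, and neither goes beyond the scatter, so 4-methylphenyl, 3-fluorophenyl and the nitro-bearing ring of compound 1 cannot be told apart at this position on this read-out. The set therefore shows that this position tolerates these three aromatic groups without a measurable difference in this assay, although what lies behind that has no support in any independent measurement here.

The three compounds leave open whether any group at this position would shift the number beyond the scatter, for example an amine or a carboxylic acid on the phenyl ring, or a longer chain in place of the methyl. Among the compounds shown here, they also do not separate the effect of the substituent from the effect of where it sits on the ring, since 4-methylphenyl has no counterpart here carrying methyl at the other ring position, and 3-fluorophenyl has none carrying fluoro elsewhere.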